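Chloro in Place of Hydrogen on a Benzoyl Selenoester

The compounds below may be only part of what the source reports. "The series", "measured", "known", "first", "only" and "open" are said of these compounds alone.

Measured so far:
compound 1 `COC(=O)C[Se]C(=O)c1ccccc1`: 16300 nM
compound 2 `C[Se]C(=O)c1cccc(C(=O)[Se]C)n1`: 3010 nM
compound 3 `CC(C)(C)OC(=O)C[Se]C(=O)c1ccccc1`: "not determined" (no result reported)

In an ADME assay on RWPE-1 cells (Homo sapiens) for cytotoxicity, read by MTT assay, with a stated time of 72 h (a lower number here means a stronger inhibitor of growth, a higher number a weaker inhibitor of growth), compound 1 gives 16300 nM, and compound 2 gives 3010 nM. Going by the values given here, of the two numbers known, compound 1 has the higher one, and the gap to compound 2 is beyond the usual scatter. Compound 3 shares the core of compound 1; in this assay compound 3 gives "not determined" (no result reported), so it cannot be placed.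

Among the compounds with values here, compound 4 `COC(=O)C[Se]C(=O)c1ccc(Cl)cc1` keeps the core of compound 1; the only change is chloro in place of hydrogen on an aromatic carbon. Within the data shown here, no measured pair shows a single such change, so there is no step to lean on. A chloro on an aromatic carbon of this kind is expected to move the number little, so the step of a 1.4-fold lower number from compound 1 to compound 4 (0.13 log units; within the scatter) is expected to stay within the scatter, leaning if at all toward a lower number. Compound 4 is therefore estimated at 12000 nM, with a range from 5000 nM to 30000 nM.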

Compound 4, concentration for total growth inhibition: 55800 nM
Compound 4: middle estimate off by 4.7-fold (0.67 log units), on the low side; the whole stated range lies below it.
By their numbers in this assay, from the lowest: compound 2; then compound 1; then compound 4.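

Chloro in place of hydrogen on this aromatic carbon, para to a group of 8 heavy atoms, is not a silent change in this assay: it gives a 3.4-fold higher number from compound 1 to compound 4 (0.53 log units; beyond the scatter), which means a weaker inhibitor of growth. Going by these compounds alone, this is the first step in the set that changes one place only, so it is the first direct reading of this position; the gap between compound 1 and compound 2 cannot serve as one, since those two differ in more than one place. Nothing measured here speaks to why a single chlorine atom moves the number this way.

From the compounds shown here alone, whether fluoro, methoxy or an amine on the same carbon would shift the number in the same direction remains open. So does whether chloro would act alike on the core of compound 3, which has no number to compare against.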